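Replacing 2-chlorophenyl with 3,4-dichlorophenyl

The source may hold more compounds than are shown below. What is called first, only, known or untested is meant among the compounds shown, and "the series" means these compounds.

Among the measured compounds shown here, in a functional assay on HeLa cells (Homo sapiens) for antiproliferative activity, read by MTT assay, with a stated time of 72 h (on this read-out higher numbers stand for weaker inhibition and lower numbers for stronger inhibition), compound 1 `Nc1nc(N)c2cc(CSC(=S)N3CCN(c4ccc(Cl)cc4)CC3)ccc2n1` gives 6990 nM and compound 2 `Nc1nc(N)c2cc(CSC(=S)N3CCN(c4ccccc4Cl)CC3)ccc2n1` gives 4050 nM, so compound 2 stands within the scatter of the only other measured value. Compound 3 `Nc1nc(N)c2cc(CSC(=S)N3CCN(c4ccc(Cl)c(Cl)c4)CC3)ccc2n1` has not yet been measured. It carries 3,4-dichlorophenyl in place of 2-chlorophenyl on an amine nitrogen in a ring, (3,4-dichlorophenyl in place of 2-chlorophenyl on an amine nitrogen in a ring). For the measured compounds named here, the only measured step that bears on this change is a 1.7-fold lower number from compound 1 to compound 2 (0.24 log units; within the scatter), where the chlorophenyl group varies at the same place. Going by the values given here, no measured compound carries the 3,4-dichlorophenyl group, so that small step is a limited guide. Among the compounds with values here, with only that step to go on, no step beyond the scatter is expected in this assay. The estimate amounts to a 1.1-fold higher number from compound 2 to compound 3 (0.05 log units; within the scatter). Compound 3 is expected at about 4500 nM, with an estimated range of 1800 nM to 11000 nM.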

Compound 3, half-maximal inhibitory concentration: 3060 nM
Compound 3: middle estimate off by 1.5-fold (0.17 log units), on the high side, and the stated range covers the measured number.
By their numbers in this assay, from the lowest: compounds 3, 2 and 1 (each within the scatter of the next, the first and the last beyond it).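

At the aryl group on the ring amine nitrogen, this assay shows a 1.3-fold lower number from compound 2 to compound 3 (0.12 log units; within the scatter), so 3,4-dichlorophenyl and 2-chlorophenyl cannot be told apart here. Adding a chloro to the 4-chlorophenyl group of compound 1 gives a 2.3-fold lower number from compound 1 to compound 3 (0.36 log units; beyond the scatter), a modest step and the first at this place to lie beyond the scatter, which shows that this position tolerates a second chlorine and that the read-out can respond to it. No measurement shown accounts for this step.

The compounds shown leave open how an unsubstituted phenyl, or a phenyl carrying methoxy or trifluoromethyl, would compare at this place. As far as these compounds go, whether a pyridine ring could stand in for the phenyl also remains open.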